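Trifluoromethyl for methoxy on the fused ring: compound 4

The source may hold more compounds than are shown below. What is called first, only, known or untested is meant among the compounds shown, and "the series" means these compounds.

Three compounds of the shared core carry numbers in a functional assay on A-375 cells (Homo sapiens) for antiproliferative activity, read by MTT assay, with a stated time of 24 h, tested at 3.7 ug/mL; a higher number here means a stronger effect of the compound at the concentration tested, a lower number a weaker effect. Compound 1 `Cc1c(C(=O)Nc2c(F)cc(-c3cccc(F)c3)cc2F)nc2ccc(C(F)(F)F)cc2c1O` gives 34.3%. Compound 2 `Cc1c(C(=O)Nc2c(F)cc(-c3cccc(F)c3)cc2F)nc2ccc(F)cc2c1C(=O)O` gives 24.5%. Compound 3 `COc1ccc2nc(C(=O)Nc3c(F)cc(-c4cccc(F)c4)cc3F)c(C)c(C(=O)O)c2c1` gives 24.6%, the second highest of the three; its nearest neighbour is compound 2 and its furthest is compound 1, and both gaps lie within the scatter.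

For the measured compounds named here, the single measured step, a number 0.1 percentage points higher from compound 2 to compound 3 (within the scatter), exchanges one group for another on the same aromatic carbon and leaves the number unchanged within the scatter.

Compound 4 `Cc1c(C(=O)Nc2c(F)cc(-c3cccc(F)c3)cc2F)nc2ccc(C(F)(F)F)cc2c1C(=O)O` changes that carbon again: trifluoromethyl in place of methoxy on an aromatic carbon. The step from compound 2 to compound 3 is the only one that bears on it, and it was flat. Among the measured compounds, compound 1 also carries trifluoromethyl but differs at a second place; compound 1 shows 34.3%, and its gap to compound 3 lies within the scatter. No step beyond the scatter is therefore expected, with no direction favoured.

Compound 4 is expected at 27%, with a range of 15% to 40%. The expected step is a number 2.4 percentage points higher from compound 3 to compound 4 (within the scatter), within the scatter.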

Compound 4, a percentage reported as inhibition, at one concentration (the size of the read-out at that concentration, not a potency): 27.8%
The estimate for compound 4 lay 0.8 percentage points below the measured number; the measured number falls inside the stated range.
By their numbers in this assay, from the lowest: compounds 2, 3, 4 and 1 (each within the scatter of the next).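

Working notes: with carboxy held, this assay now covers three groups on this aromatic carbon, and both a number 3.2 percentage points higher from compound 3 to compound 4 (within the scatter) and a number 3.3 percentage points higher from compound 2 to compound 4 (within the scatter) join the earlier flat step, so fluoro, methoxy and trifluoromethyl cannot be told apart here. For the compounds shown here, with trifluoromethyl held, the change at the other place can now be read for the first time: a number 6.5 percentage points lower from compound 1 to compound 4 (within the scatter) for carboxy in place of hydroxy on an aromatic carbon, so this exchange does not separate the two compounds either. Nothing measured here offers a cause for any of these steps.

As far as these compounds go, whether an amine, a nitrile or a longer chain on this aromatic carbon would give a step beyond the scatter remains open. Also open, from the compounds shown here alone, is whether the carboxy and hydroxy exchange stays flat with fluoro or methoxy in place of trifluoromethyl.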